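Dimethylamino to Diethylamino on a Carbonyl Carbon

The source may report more compounds than this note shows. Statements on the series, on what has been measured and on what is new or still open speak of the compounds shown alone.

- compound 1 `CC(=O)OC1=C(c2cccc3cccnc23)Oc2cc3ccccc3cc2-n2cccc21` gives 263 nM
- compound 2 `CN(C)C(=O)OC1=C(c2cccc3cccnc23)Oc2cc3ccccc3cc2-n2cccc21` gives 300 nM

Both numbers come from a functional assay on HL-60 cells (Homo sapiens) for cytotoxicity, read by resazurin assay, with a stated time of 72 h (a lower number here means a stronger inhibitor, a higher number a weaker inhibitor), and lie so close that repeated measurements could not separate them. On the evidence so far, compound 2 stands level with compound 1.

The next compound is compound 3 `CCN(CC)C(=O)OC1=C(c2cccc3cccnc23)Oc2cc3ccccc3cc2-n2cccc21`, which keeps the shared core but carries diethylamino in place of dimethylamino on a carbonyl carbon. The full count of that change is diethylamino in place of dimethylamino on a carbonyl carbon and nothing else differs.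

Within the data shown here, only one measured step bears on this change. Putting dimethylamino in place of methyl on the same carbonyl carbon gave a 1.1-fold higher number from compound 1 to compound 2 (0.06 log units; within the scatter) and so stayed inside the normal noise of the measurement. That is a single step of a different kind, which makes it thin evidence, but it gives no reason to look for a large shift in either direction. The expected result in this assay is a 1.1-fold higher number from compound 2 to compound 3 (0.03 log units; within the scatter) and so no change beyond the scatter. Compound 3 is expected at 320 nM with an estimated range from 140 nM to 720 nM around that figure.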

Compound 3, half-maximal inhibitory concentration: 4580 nM
The estimate for compound 3 lay 14-fold (1.16 log units) below the measured number, outside the stated range (above it).
By their numbers in this assay, from the lowest: compounds 1 and 2 (each within the scatter of the next); then compound 3.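

Diethylamino on this carbonyl carbon is not a neutral swap, although methyl and dimethylamino there could not be told apart. In this assay the move from dimethylamino to diethylamino, which takes the group from 3 heavy atoms to 5 and adds only carbon, gives a 15-fold higher number from compound 2 to compound 3 (1.18 log units; beyond the scatter), and the comparison with methyl gives a 17-fold higher number from compound 1 to compound 3 (1.24 log units; beyond the scatter), so this position can respond strongly to a small edit even where an earlier change left the number within the scatter. Nothing measured here explains why the two ethyl groups weaken the compound so much.

Three compounds cannot show whether the loss sets in gradually or appears abruptly, and ethylmethylamino on the same carbonyl carbon would sit directly between dimethylamino and diethylamino to test this. From the compounds shown here alone, it also remains open whether the loss depends on the two ethyl chains being free or on the nitrogen, which a pyrrolidine ring or a plain propyl chain on that carbonyl carbon would help to separate.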